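The source may report more compounds than this note shows. Statements on the series, on what has been measured and on what is new or still open speak of the compounds shown alone.

Compound 1 `COc1ccc(C(=O)Nc2cccc(-c3oc4cc(-c5ccc(F)cc5)ccc4c(=O)c3O)c2)cc1` was tested in a functional assay on A549 cells (Homo sapiens) for antiproliferative activity, read by CCK-8 assay, with a stated time of 72 h (on this read-out higher numbers stand for weaker inhibition and lower numbers for stronger inhibition), where compound 1 gives 8700 nM. Compound 2 `O=C(Nc1cccc(-c2oc3cc(-c4ccc(F)cc4)ccc3c(=O)c2O)c1)c1ccc(F)cc1F` carries a different ring on the carbonyl carbon; in this assay compound 2 gives 20500 nM. Among the two measured compounds, compound 1 stands lowest, and the single recorded step, a 2.4-fold higher number from compound 1 to compound 2 (0.37 log units; beyond the scatter), is modest. Compound 3 `O=C(Nc1cccc(-c2oc3cc(-c4ccc(F)cc4)ccc3c(=O)c2O)c1)c1ccc(Br)cc1` has not yet been measured. It differs from compound 1 at one place: bromo in place of methoxy on an aromatic carbon. For the measured compounds named here, the only step that bears on this change is a 2.4-fold higher number from compound 1 to compound 2 (0.37 log units; beyond the scatter), which also swapped the 4-methoxyphenyl on the carbonyl carbon for a ring bearing fluorine and weakened inhibition modestly. A comparably small weakening is therefore expected for compound 3, one that may stay within the scatter. Compound 3 is expected to give 13000 nM, in a range from 5000 nM to 32000 nM, with an expected step of a 1.5-fold higher number from compound 1 to compound 3 (0.17 log units; within the scatter).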

Compound 3, half-maximal inhibitory concentration: 13500 nM
Compound 3: the middle estimate sits 1.0-fold (0.02 log units) below what was measured; the range from low to high includes it.
By their numbers in this assay, from the lowest: compounds 1, 3 and 2 (each within the scatter of the next, the first and the last beyond it).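

Replacing methoxy with bromo on this aromatic carbon, para to a large group, gives a 1.6-fold higher number from compound 1 to compound 3 (0.19 log units; within the scatter) in this assay, so a swap of these two groups on this ring leaves the number within normal variation. The other comparison, a 1.5-fold lower number from compound 2 to compound 3 (0.18 log units; within the scatter), shows that 4-bromophenyl and 2,4-difluorophenyl also cannot be told apart here, so the bromo compound sits within the scatter of both neighbours, although those neighbours differ from each other by more than the scatter. Nothing available explains why these groups give such similar numbers.

The compounds shown leave open whether an amine or a carboxylic acid at this position would shift the number beyond the scatter. They also leave open what a longer chain, such as butoxy, or a bare phenyl ring would do.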